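The source may report more compounds than this note shows. Statements on the series, on what has been measured and on what is new or still open speak of the compounds shown alone.

Compound 1 `O=C1C(NC2CCCC2)=CC(=O)c2c1nc1n2[C@H]2OC[C@@H](O)[C@H]2OC1`: > 16000 nM, a limit.
Compound 2 `Cc1ccc(NC2=CC(=O)c3c(nc4n3[C@H]3OC[C@@H](O)[C@H]3OC4)C2=O)cc1C`: 4950 nM.

For the measured compounds named here, in a functional assay on MCF7 cells (Homo sapiens) for inhibition, read by sulforhodamine B assay (a lower number here means a stronger inhibitor, a higher number a weaker inhibitor), compound 2 gives 4950 nM, the only actual number so far. Compound 3 `O=C1C(N2CCC2)=CC(=O)c2c1nc1n2[C@H]2OC[C@@H](O)[C@H]2OC1` has azetidin-1-yl in place of (3,4-dimethylphenyl)amino on a double-bonded ring carbon. Going by the values given here, the one measured step that bears on this is an at least 3.2-fold lower number from compound 1 to compound 2 (0.50 log units; beyond the scatter), beyond the scatter, with 3,4-dimethylphenyl replacing cyclopentyl on an amine nitrogen. Compound 3 also lacks the 3,4-dimethylphenyl, so a step of similar size towards a higher number is expected in this assay. The expected change is a 3.0-fold higher number from compound 2 to compound 3 (0.48 log units; beyond the scatter). Compound 3 is estimated at 15000 nM, with a range of 5000 nM to 45000 nM.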

Compound 3, half-maximal inhibitory concentration: > 16000 nM
Compound 3 was reported as a limit; the forecaster's own chance of this, stated with the estimate: 50%; middle value at least 1.0-fold (0.02 log units) away from the limit.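

In this assay, replacing the (3,4-dimethylphenyl)amino group gives an at least 3.2-fold higher number from compound 2 to compound 3 (0.50 log units; beyond the scatter). Thus, a second group lacking the 3,4-dimethylphenyl, here a ring-bound nitrogen with no hydrogen-bond donor, also gives no number, leaving compound 2 the only one of the three with a measured value. The step from compound 1 to compound 3 cannot be read, as both values are limits: the limit of > 16000 nM in this assay, at which 2 of the 3 values shown sit.

As far as these compounds go, whether the aromatic ring, its two methyl groups or the amine hydrogen of compound 2 matters most stays open. A plain phenylamino or a benzylamino group would bear on this.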